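The source may report more compounds than this note shows. Statements on the series, on what has been measured and on what is new or still open speak of the compounds shown alone.

Measured so far in a physicochemical assay for solubility, at pH 7.4; on this read-out higher numbers stand for higher solubility and lower numbers for lower solubility:

- Compound 1 `Cc1c2c(n3c1CCN(C(=O)CN)C[C@@H](C)[C@H](C)Nc1cc-3ccc1C(N)=O)CC(C)(C)CC2=O` gives 46 ug/mL
- Compound 2 `Cc1c2c(n3c1CCN(C(=O)C1(N)CCCC1)C[C@@H](C)[C@H](C)Nc1cc-3ccc1C(N)=O)CC(C)(C)CC2=O` gives 53 ug/mL

In this assay compound 2 stands at 53 ug/mL and is level with compound 1 within the scatter. Compound 3 `Cc1c2c(n3c1CCN(C(=O)[C@H](C)O)C[C@@H](C)[C@H](C)Nc1cc-3ccc1C(N)=O)CC(C)(C)CC2=O` carries 1-hydroxyethyl in place of 1-aminocyclopentyl on a carbonyl carbon. Going by the values given here, the only measured step that bears on this is a 1.2-fold higher number from compound 1 to compound 2 (0.06 log units; within the scatter) and it exchanges one nitrogen-bearing group for another. Among the compounds with values here, no measured step takes that nitrogen away, so the guide is thin. The expected step is a 1.8-fold lower number from compound 2 to compound 3 (0.25 log units; within the scatter) and the tentative lean is towards a lower number. Compound 3 is estimated at 30 ug/mL with an expected range of 10 ug/mL to 85 ug/mL.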

Compound 3, solubility: 60 ug/mL
Beside the measured number, compound 3's estimate is 2.0-fold (0.30 log units) below it, and the stated range covers the measured number.
By their numbers in this assay, from the lowest: compounds 1, 2 and 3 (each within the scatter of the next).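

In this assay, 1-hydroxyethyl in place of 1-aminocyclopentyl on a carbonyl carbon gives a small step (a 1.1-fold higher number from compound 2 to compound 3 (0.05 log units; within the scatter)), and the exchange for aminomethyl gives another (a 1.3-fold higher number from compound 1 to compound 3 (0.12 log units; within the scatter)). A group without nitrogen or a ring therefore sits level with both nitrogen-bearing groups, which the earlier pair, both carrying nitrogen, could not show. No available measurement explains this result. Still open, from the compounds shown here alone, is whether a carboxylic acid or a longer chain at this place would stay level too, and whether the mirror-image form of 1-hydroxyethyl would match compound 3.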